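Aryl in place of ethyl on the sulfonamide carbon

The source may hold more compounds than are shown below. What is called first, only, known or untested is meant among the compounds shown, and "the series" means these compounds.

Compound 2 `CCCS(=O)(=O)NCc1cnc2scc(-c3ccc(Br)cc3)n12` gives 1070 nM in an assay on cells for inhibition of Indoleamine 2,3-dioxygenase 1 (Homo sapiens); a lower number here means a stronger inhibitor, a higher number a weaker inhibitor. For the measured compounds named here, of the two numbers measured so far it holds the higher one, but its only neighbour, compound 1 `O=S(=O)(Cc1cccc(Cl)c1)NCc1cnc2scc(-c3ccc(Br)cc3)n12`, gives 744 nM, and the step of a 1.4-fold higher number from compound 1 to compound 2 (0.16 log units; within the scatter) lies within the scatter, so the two compounds cannot be told apart on these data. Compound 3 `Cc1ccc(CS(=O)(=O)NCc2cnc3scc(-c4ccc(Br)cc4)n23)cc1` differs from compound 2 by 4-methylphenyl in place of ethyl on a saturated chain carbon bound to a sulfonyl sulfur. Going by the values given here, the one measured step that bears on this change is the step of a 1.4-fold higher number from compound 1 to compound 2 (0.16 log units; within the scatter), which exchanged a ring for a saturated chain at the same carbon and stayed within the scatter; the change to compound 3 runs in the opposite sense with a differently substituted ring. No step beyond the scatter is therefore expected, a 1.3-fold lower number from compound 2 to compound 3 (0.13 log units; within the scatter), and compound 3 is expected to sit close to both measured compounds. The estimate for compound 3 is 800 nM, with a range from 400 nM to 1600 nM.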

Compound 3, half-maximal inhibitory concentration: 855 nM
Compound 3: middle estimate off by 1.1-fold (0.03 log units), on the low side; low and high end bracket the measured number.
By their numbers in this assay, from the lowest: compounds 1, 3 and 2 (each within the scatter of the next).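

In this assay, a substituted phenyl ring in place of ethyl on the saturated chain carbon bound to the sulfonyl sulfur stays within the scatter (a 1.3-fold lower number from compound 2 to compound 3 (0.10 log units; within the scatter)), which adds a second ring-for-chain exchange to the first one. Changing the ring itself also stays within the scatter (a 1.1-fold higher number from compound 1 to compound 3 (0.06 log units; within the scatter)), so 4-methylphenyl and 3-chlorophenyl cannot be told apart here, and ethyl, 3-chlorophenyl and 4-methylphenyl at this place all give numbers of one level on the shared core. Nothing on hand accounts for this flat reading.

As far as these compounds go, whether an amine or a carboxylic acid at this place would give a step beyond the scatter remains open. All the compounds shown keep the same core, so whether the flat reading holds on any other core is also open.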